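Swapping a fluoropyridinyl arm for a methyl on a sulfone

The source may hold more compounds than are shown below. What is called first, only, known or untested is meant among the compounds shown, and "the series" means these compounds.

Measured compounds:
- compound 1 `CCCCc1nc(=O)c(S(=O)(=O)c2ccc(-c3cccnc3)cc2)c(O)n1-c1c(OC)cccc1OC`: 57%
- compound 2 `CCCCc1nc(=O)c(S(=O)(=O)c2ccc(-c3ccc(F)nc3)cc2)c(O)n1-c1c(OC)cccc1OC`: 69%

Among the measured compounds shown here, in an ADME assay on microsomes from liver (Mus musculus) for metabolic stability, using NADPH, with a stated time of 10 min (a lower number here means that less of the compound is left, a higher number that more of the compound is left), compound 2 gives the higher of the two numbers measured so far, and its only neighbour is compound 1, which gives 57%. For the measured compounds named here, the one step that has been measured, a number 12 percentage points higher from compound 1 to compound 2 (beyond the scatter), is a modest gain that lies beyond the scatter.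

Compound 3 `CCCCc1nc(=O)c(S(=O)(=O)c2ccc(C)cc2)c(O)n1-c1c(OC)cccc1OC` has not yet been measured. Its change from compound 2 is methyl in place of 6-fluoropyridin-3-yl on an aromatic carbon. The measured step bears on this only in part: it shows that the fluorine on the pyridine ring of compound 2 was worth something in this assay, but nothing measured tells how the whole fluoropyridinyl group compares with a methyl. With the fluorine gone along with the ring it sat on, the gain seen in compound 2 is not expected to carry over, so a step of the size a number 14 percentage points lower from compound 2 to compound 3 (beyond the scatter) downward is expected, with wide uncertainty. For compound 3 the expected value in this assay is 55%, within a range from 30% to 80%.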

Compound 3, percent of the compound remaining: 80%
For compound 3 the middle estimate is 25 percentage points below the measured one; the range from low to high includes it.
By their numbers in this assay, from the lowest: compound 1; then compound 2; then compound 3.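

At this place, on an aromatic carbon para to a large group, a ring is not required for a high number in this assay: methyl, with its single carbon, gives a number 11 percentage points higher from compound 2 to compound 3 (beyond the scatter) and also a number 23 percentage points higher from compound 1 to compound 3 (beyond the scatter) when it replaces the unfluorinated ring. The earlier step showed only that adding fluorine improved the pyridine arm, whereas these two steps show that replacing either arm with methyl does more, and the three compounds now rank with the ringless compound 3 on top. So the fluorine gain was real, but it did not make up for whatever separates a pyridine arm from a methyl, and no other measurement is available to say what that is.

From the compounds shown here alone, two very different groups are compared here, so it remains open whether the number depends on the presence of the ring, on the count of atoms, or on something else; an ethyl group, a chlorine atom, a methoxy group or a plain phenyl ring at the same place would each test a different part of that question. Going by these compounds, it is also open whether the order of compound 1, compound 2 and compound 3 would hold in any other kind of test.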